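Cyclopropyl replaces dimethoxyphenyl on the amide nitrogen

The source may report more compounds than this note shows. Statements on the series, on what has been measured and on what is new or still open speak of the compounds shown alone.

Among the measured compounds shown here, compound 3 `COc1cc(NC(=O)c2cccc(N3C(=O)c4ccccc4C3=O)c2)cc(OC)c1` is the one member of this small set for which an in vitro functional assay on HEK293-A cells for antagonist activity at metabotropic glutamate receptor 5 (Rattus norvegicus), read by calcium flux (a higher number here means a weaker inhibitor, a lower number a stronger inhibitor), returns a number: compound 3 gives 3580 nM. Compound 1 `COc1ccccc1C(=O)Nc1cccc(NC(=O)c2ccco2)c1` reaches only a limit of the assay, > 30000 nM. Compound 2 `O=C(Nc1cccc(NC(=O)c2cccc(Cl)c2)c1)c1cccc(F)c1` likewise stops at a limit, > 30000 nM. For the measured compounds named here, compound 3 therefore stands alone as the only quantified value, while the other two sit at the limit of > 30000 nM in this assay, at which 2 of the 3 values shown sit.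

The step to compound 4 `O=C(NC1CC1)c1cccc(N2C(=O)c3ccccc3C2=O)c1` is cyclopropyl in place of 3,5-dimethoxyphenyl on an amide-type nitrogen whose other neighbour is a carbonyl carbon. Going by the values given here, no pair of measured compounds here differs in a single place, so no measured step gives a scale for a change of this kind, and the two limits say nothing about how far compound 3 can be moved in either direction.

The step from compound 3 to compound 4 is estimated here at a 4.2-fold higher number from compound 3 to compound 4 (0.62 log units; beyond the scatter) in this assay, towards a weaker inhibitor and beyond the scatter. For compound 4 the expected value in this assay is 15000 nM, with a range from 5000 nM to 30000 nM, and a real chance that the assay reports only a limit.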

Compound 4, half-maximal inhibitory concentration: > 30000 nM
Compound 4: a limit, no number; the forecaster's own chance of this, stated with the estimate: 50%; middle value at least 2.0-fold (0.30 log units) away from the limit.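

In this assay, among the compounds shown here, putting cyclopropyl in place of 3,5-dimethoxyphenyl on the amide-type nitrogen gives an at least 8.3-fold higher number from compound 3 to compound 4 (0.92 log units; beyond the scatter), the first measured step in this set and one towards a weaker inhibitor. It shows that, on the core of compound 3, measurable inhibition in this assay does not survive this exchange, so the group on this nitrogen matters, although the step rests on a limit and fixes only a minimum size for the change. Compound 3 remains the only compound with a number, and the limit now covers every other compound shown: the limit of > 30000 nM in this assay, at which 3 of the 4 values shown sit.

As far as these compounds go, whether the difference lies with the methoxy groups or with the aromatic ring itself stays open, and an unsubstituted phenyl or a cyclohexyl on the same nitrogen would begin to separate the two. From the compounds shown here alone, it is also open whether any other group at this place, such as a pyridyl ring or a 3,5-dichlorophenyl, would give a stronger inhibitor than compound 3, which stands at 3580 nM.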